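This account rests on a few compounds, and the source may have more. Where it says the series, first, only, none or still open, it means among the compounds named here.

Compound 1, `CNc1nc(Cl)nc2c1ncn2[C@H]1C[C@H](OP(=O)(O)O)[C@]2(COP(=O)(O)O)C[C@H]12`: 2.5 nM
Compound 2, `Nc1nc(I)nc2c1ncn2C1CC(OP(=O)(O)O)[C@]2(COP(=O)(O)O)C[C@H]12`: 12.6 nM

In an in vitro assay on Sf9 cells for binding affinity to P2Y purinoceptor 1 (Homo sapiens) (a higher number here means a weaker inhibitor, a lower number a stronger inhibitor), compound 1 gives 2.5 nM, the lower of the two numbers shown; compound 2 gives 12.6 nM, a higher number that lies beyond the usual scatter. Compound 3, `CNc1ncnc2c1ncn2[C@H]1C[C@H](OP(=O)(O)O)[C@]2(COP(=O)(O)O)C[C@H]12`, has not yet been measured. It differs from compound 1 in one place: hydrogen in place of chloro on an aromatic carbon. Going by the values given here, no measured pair shows this exact change, so the step can only be anticipated from the change itself. Compared with compound 1, compound 3 is expected to give a higher number, a step of a 6.0-fold higher number from compound 1 to compound 3 (0.78 log units; beyond the scatter) that lies beyond the scatter. Compound 3 is estimated at 15 nM, within a range from 4 nM to 60 nM.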

Compound 3, inhibition constant: 17.6 nM
Compound 3: the middle estimate sits 1.2-fold (0.07 log units) below what was measured, within the range that was stated.
By their numbers in this assay, from the lowest: compound 1; then compounds 2 and 3 (each within the scatter of the next).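

In this assay, replacing the chloro with hydrogen on the aromatic carbon between two ring nitrogen atoms gives a weaker inhibitor (a 7.0-fold higher number from compound 1 to compound 3 (0.85 log units; beyond the scatter)). Going by these compounds alone, this is the first direct reading of this change, and it shows that the group on this carbon matters for binding, since the step lies beyond the usual scatter. Nothing shown here explains why the number rises.

On these data alone, whether a bromo, a methyl group or an amine on this carbon would match the chloro stays open. So does whether the step would be the same size with another group in place of the methylamino group.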